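Adding a hydroxy to compound 2: expected antiproliferative effect

This account rests on a few compounds, and the source may have more. Where it says the series, first, only, none or still open, it means among the compounds named here.

Measured in a functional assay on HeLa cells (Homo sapiens) for antiproliferative activity, read by MTT assay, with a stated time of 48 h; on this read-out higher numbers stand for weaker inhibition and lower numbers for stronger inhibition:
- compound 1 `Oc1ccc2cc1Oc1cccc(c1)CCc1ccc(O)c(c1)Oc1ccc(cc1O)CC2`: 19500 nM
- compound 2 `Oc1ccc2cc1Oc1ccc(cc1)CCc1ccc(O)c(c1)Oc1ccc(cc1)CC2`: 22700 nM

The values of compound 2 and compound 1 lie within the scatter of each other, so neither stands apart. Compound 3 `Oc1ccc2cc1Oc1ccc(cc1)CCc1ccc(O)c(c1)Oc1ccc(cc1O)CC2` differs from compound 2 in one place: hydroxy in place of hydrogen on an aromatic carbon. Among the measured compounds shown here, no measured pair differs in only one place, so the data give no direct size for this change. The expected change is a 1.3-fold lower number from compound 2 to compound 3 (0.13 log units; within the scatter) in this assay, slightly toward stronger inhibition and not beyond the scatter. Compound 3 is estimated at 17000 nM, with an expected range from 8000 nM to 35000 nM.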

Compound 3, half-maximal inhibitory concentration: 29500 nM
Beside the measured number, compound 3's estimate is 1.7-fold (0.24 log units) below it; the measured number falls inside the stated range.
By their numbers in this assay, from the lowest: compounds 1, 2 and 3 (each within the scatter of the next).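

In this assay, among the compounds shown here, hydroxy in place of hydrogen on an aromatic carbon gives a 1.3-fold higher number from compound 2 to compound 3 (0.11 log units; within the scatter), the first step that can be read for one place alone. At this carbon, ortho to a fused ring and meta to a fused ring, the added hydroxy leaves the number within the scatter, so this step shows no gain or loss of antiproliferative effect.

The compounds shown leave open whether a methoxy, an amine or a carboxylic acid at this carbon would move the number beyond the scatter. No measurement at hand bears on the reason for this result.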